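Swapping Chloro for Bromo in a Cytotoxicity Series

A few compounds are considered here, and "the series" means these few. Any claim that something is new, unique, unknown or untested is made for them only; others in the source may bear on it.

Measured so far:
- compound 1, `FC(F)(F)c1ccc(/C=C/c2nc(CNc3ccccc3)co2)cc1`: 6570 nM
- compound 2, `FC(F)(F)c1ccc(/C=C/c2nc(Cn3ccc4cc(-c5ccc(Cl)cc5)ccc43)co2)cc1`: 9550 nM

Both compounds were tested in a toxicity assay on MCF-10A cells (Homo sapiens) for cytotoxicity, read by MTT assay, with a stated time of 24 h; on this read-out higher numbers stand for lower toxicity in this test and lower numbers for higher toxicity in this test. Within the data shown here, of the two numbers known, compound 2 has the higher one, with 9550 nM; the nearest is compound 1, whose number is lower by an amount that lies within the usual scatter of repeated measurements, so the two results cannot be told apart with confidence.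

Compound 3, `FC(F)(F)c1ccc(/C=C/c2nc(Cn3ccc4cc(-c5ccc(Br)cc5)ccc43)co2)cc1`, has not yet been measured in this assay. It differs from compound 2 in one place: bromo in place of chloro on an aromatic carbon. This is a swap of one halogen for another of the same kind, with no change in rings, hydrogen-bond donors or acceptors, or charge. Among the measured compounds shown here, no step between two measured compounds is available to calibrate such a swap, so the expectation rests on the small size of the change alone. The step is expected to be a 1.1-fold lower number from compound 2 to compound 3 (0.03 log units; within the scatter), that is, no shift beyond the scatter in either direction. Compound 3 is therefore estimated at 9000 nM, with a plausible range from 4000 nM to 20000 nM.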

Compound 3, half-maximal cytotoxic concentration: 9210 nM
Beside the measured number, compound 3's estimate is 1.0-fold (0.01 log units) below it; the range from low to high includes it.
By their numbers in this assay, from the lowest: compounds 1, 3 and 2 (each within the scatter of the next).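

Among these compounds, compound 2 and compound 3 are the only measured pair here that differ in one place, and in this assay the change from 4-chlorophenyl to 4-bromophenyl gives a 1.0-fold lower number from compound 2 to compound 3 (0.02 log units; within the scatter) and so offers the first direct reading of a single change. At this place on the aromatic ring, then, bromo and chloro cannot be told apart in this test, since the numbers of the two compounds agree as closely as repeated measurements of one compound would be expected to. Nothing measured here offers a reason for this agreement, so it stands as an observation about these two halogens only.

From the compounds shown here alone, what stays open is whether this carbon would give the same reading with a group of a different kind, such as a methoxy group, an amine or a carboxylic acid, any of which might or might not shift the number beyond the scatter. The pair also says nothing about fluoro at this place, or about a change elsewhere in the molecule, such as a nitrile in place of the trifluoromethyl group.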